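From neopentyl to cyclopentylmethyl on a shared core

The compounds below may be only part of what the source reports. "The series", "measured", "known", "first", "only" and "open" are said of these compounds alone.

Compound 1 (`CN1CCc2c(sc(NC(=O)Nc3ccc(Cl)cc3)c2C(N)=O)C1`): 4700 nM
Compound 2 (`CC(C)(C)CN1CCc2c(sc(NC(=O)Nc3ccc(Cl)cc3)c2C(N)=O)C1`): 5560 nM

Within the data shown here, in a functional assay (strain AB) with Danio rerio as the target, read by microscopy, with a stated time of 1 h (a higher number here means that more compound is needed for the effect, a lower number that less compound is needed), compound 2 gives 5560 nM, a number within the scatter of that of compound 1, the only other compound measured. Compound 3 (`NC(=O)c1c(NC(=O)Nc2ccc(Cl)cc2)sc2c1CCN(CC1CCCC1)C2`) carries cyclopentyl in place of tert-butyl on a saturated chain carbon bound to an amine nitrogen in a ring. Among the measured compounds shown here, one measured step bears on this change: a 1.2-fold higher number from compound 1 to compound 2 (0.07 log units; within the scatter), where tert-butyl took the place of hydrogen on that same carbon. For the measured compounds named here, no compound with a ring at this place has been measured, so the evidence is thin. Going by the values given here, with only that small step to go on, no change beyond the scatter is expected in this assay. The estimated step is a 1.1-fold lower number from compound 2 to compound 3 (0.05 log units; within the scatter). For compound 3 the estimated value is 5000 nM, with an expected range from 2500 nM to 10000 nM.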

Compound 3, half-maximal effective concentration: 1830 nM
Compound 3: middle estimate off by 2.7-fold (0.44 log units), on the high side; the measured number lies below the stated range.
By their numbers in this assay, from the lowest: compound 3; then compounds 1 and 2 (each within the scatter of the next).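

Neopentyl to cyclopentylmethyl is the first change on a saturated chain carbon bound to an amine nitrogen in a ring to move the number in this assay beyond the scatter, with a 3.0-fold lower number from compound 2 to compound 3 (0.48 log units; beyond the scatter). Cyclopentyl in place of hydrogen on that carbon gives a 2.6-fold lower number from compound 1 to compound 3 (0.41 log units; beyond the scatter), whereas tert-butyl there left the number within the scatter, so among these three compounds the lower number goes with the five-membered ring and not with any larger group at this place. Nothing available accounts for this difference between cyclopentyl and tert-butyl.

The compounds shown leave open whether a cyclobutyl or cyclohexyl group would give a similar number. They also leave open whether an open pentyl chain, or a ring holding an ether oxygen, would do the same.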